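A Heptyl Tail in Place of a Fluorophenyl Amide

The source may hold more compounds than are shown below. What is called first, only, known or untested is meant among the compounds shown, and "the series" means these compounds.

Of the compounds shown here, three built on a shared core have been tested in a functional assay on A549 cells (Homo sapiens) for inhibition, read by MTT assay, with a stated time of 24 h; a lower number here means a stronger inhibitor, a higher number a weaker inhibitor. The first of them is compound 1, `CCOC(=O)C1=Cc2ccccc2OC1(OCc1cn(CC(=O)Nc2cccc(F)c2)nn1)C(F)(F)F`. In this assay compound 1 gives only a limit, > 150000 nM, and not a number. Compound 2, `O=C(O)C1=Cc2ccccc2OC1(OCc1cc(-c2ccc([N+](=O)[O-])cc2)no1)C(F)(F)F`, likewise stops at a limit in this assay, > 150000 nM. Compound 3, `CCOC(=O)C1=Cc2ccccc2OC1(OCc1cc(-c2ccc3ccccc3c2)no1)C(F)(F)F`, also reaches only a limit in this assay, > 150000 nM. Compound 1 therefore stands exactly where the others stand: the limit of > 150000 nM in this assay, at which 3 of the 3 values shown sit. None of the three has shown measurable inhibition of the cells.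

Compound 4, `CCCCCCCCn1cc(COC2(C(F)(F)F)Oc3ccccc3C=C2C(=O)OCC)nn1`, is not yet measured. It differs from compound 1 in a single place: heptyl in place of (3-fluorophenyl)carbamoyl on a saturated chain carbon bound to an aromatic nitrogen The (3-fluorophenyl)carbamoyl group is removed and a heptyl chain takes its position on the saturated chain carbon bound to the aromatic nitrogen.

Among the measured compounds shown here, no measured pair shows what such a swap does here. With every value shown sitting at the limit, no direction can be read from the data, and the expected step is a step that the limit leaves unreadable from compound 1 to compound 4, none beyond the scatter. Compound 4 is therefore estimated to give 200000 nM in this assay, within 50000 nM to 800000 nM, and most likely to be reported once more only as a limit.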

Compound 4, half-maximal inhibitory concentration: > 150000 nM
Compound 4 gave a limit, no number (the forecaster's own chance of this, stated with the estimate: 85%); the middle value lies beyond the limit too.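

In this assay compound 4 gives > 150000 nM as a limit and not a number. Among the compounds shown here, compound 1 also stops at a limit, so no step from compound 1 to compound 4 can be read. The compounds shown leave open whether heptyl in place of (3-fluorophenyl)carbamoyl changes anything, and whether any compound on this shared core gives a measurable value: the limit of > 150000 nM in this assay, at which 4 of the 4 values shown sit.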